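Three inactive polyprenylated ketones and a single inversion

A few compounds are considered here, and "the series" means these few. Any claim that something is new, unique, unknown or untested is made for them only; others in the source may bear on it.

Compound 1 `CC(C)=CCCC(=O)[C@]1(/C=C/C(C)C)C[C@H](CC=C(C)C)C(C)(C)[C@@H](C(=O)c2ccccc2)C1=O` gives > 10000 nM in a functional assay on KMS-11 cells (Homo sapiens) for cytotoxicity, read by CellTiter-Glo, with a stated time of 5 days (a higher number here means a weaker inhibitor, a lower number a stronger inhibitor), a limit of the assay rather than a number.
Compound 2 `COC(=O)[C@@]1(CC=C(C)C)C[C@H](CC=C(C)C)C(C)(C)[C@H](C(=O)C(C)C)C1=O` gives > 10000 nM in this assay, again a limit.
Compound 3 `CC(C)=CC[C@@H]1C[C@H](CC=C(C)C)C(C)(C)[C@H](C(=O)C(C)C)C1=O` gives > 10000 nM in this assay, also a limit.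

Compound 3 therefore stands nowhere that can be ranked: its value is a limit, and both other values shown are limits as well, so no order among compounds 1, 2 and 3 can be read. For the measured compounds named here, the one line of supporting evidence is the limit of > 10000 nM in this assay, at which 3 of the 3 values shown sit, which simply records that every value shown sits at the same limit.

Compound 4 `CC(C)=CC[C@@H]1C[C@H](CC=C(C)C)C(C)(C)[C@@H](C(=O)C(C)C)C1=O` has not yet been measured in this assay. It differs from compound 3 as follows: the two compounds have the same atoms and bonds and differ only in configuration as drawn: 1 of 3 stereo elements differ; a stereocentre at a saturated ring carbon is drawn R in compound 3 and S in compound 4. No step between measured compounds is shown, so the size of this change cannot be calibrated against a measured pair. Compound 3 sits at the limit, and compound 4 shares its atoms and bonds; the step from compound 3 to compound 4 is expected to be a step that the limit leaves unreadable from compound 3 to compound 4, that is, no shift beyond the scatter. Compound 4 is accordingly estimated at 15000 nM, within 5000 nM to 50000 nM, with a limit the most likely outcome.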

Compound 4, half-maximal inhibitory concentration: > 10000 nM
Compound 4 gave a limit, no number; the forecaster's own chance of this, stated with the estimate: 85%; the middle value lies beyond the limit too.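

In this assay compound 4 gives > 10000 nM, which is a limit. Compound 3 also sits at a limit, so no step can be read between these two compounds. The compounds shown leave open whether the configuration at this saturated ring carbon affects cytotoxicity at all, and what would produce a measurable value: the limit of > 10000 nM in this assay, at which 4 of the 4 values shown sit.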